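Estimating Compound 3 From a Single Large Step

A few compounds are considered here, and "the series" means these few. Any claim that something is new, unique, unknown or untested is made for them only; others in the source may bear on it.

Compound 1 `COc1ccc(C(=O)/C=C/c2nc3ccccc3cc2-c2ccc(OC)cc2)cc1`: 9280 nM
Compound 2 `COc1ccc(-c2cc3ccccc3nc2/C=C/C(=O)c2ccc([N+](=O)[O-])cc2)cc1`: 590 nM

Going by the values given here, of the two measured compounds, compound 2 holds the lower number in a functional assay on SK-BR-3 cells (Homo sapiens) for antiproliferative activity, read by XTT assay, with a stated time of 72 h; on this read-out higher numbers stand for weaker inhibition and lower numbers for stronger inhibition; the only measured step, a 16-fold lower number from compound 1 to compound 2 (1.20 log units; beyond the scatter), separates it from compound 1. Compound 3 `COc1ccc(-c2cc3ccccc3nc2/C=C/C(=O)c2ccc(Br)s2)cc1` differs from compound 2 by 5-bromothiophen-2-yl in place of 4-nitrophenyl on a carbonyl carbon. No measured step swaps this whole ring, but the one step shown touches the same carbonyl-bound ring and was large, so a step beyond the scatter in this assay is expected, its direction uncertain. Compound 3 is estimated at 1800 nM, within 400 nM to 8000 nM, meaning an expected 3.1-fold higher number from compound 2 to compound 3 (0.48 log units; beyond the scatter).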

Compound 3, half-maximal inhibitory concentration: 520 nM
The estimate for compound 3 lay 3.5-fold (0.54 log units) above the measured number; the range from low to high includes it.
By their numbers in this assay, from the lowest: compounds 3 and 2 (each within the scatter of the next); then compound 1.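

On the carbonyl carbon, replacing the whole ring gives a 1.1-fold lower number from compound 2 to compound 3 (0.05 log units; within the scatter) in this assay, so 5-bromothiophen-2-yl and 4-nitrophenyl cannot be told apart here, although they differ in ring size and atoms. Compound 1, with 4-methoxyphenyl at this place, remains separate from both, and the change to the bromothiophene gives an 18-fold lower number from compound 1 to compound 3 (1.25 log units; beyond the scatter) as a second large step. No measurement shown explains why these different rings give matching numbers. On these data alone, it remains open how a plain thiophene without bromine would behave, or a phenyl ring carrying an amine or a carboxylic acid.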